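Removing sulfamoyl: compound 2 to compound 3

The source may report more compounds than this note shows. Statements on the series, on what has been measured and on what is new or still open speak of the compounds shown alone.

Measured in an ADME assay (liver) for metabolic stability, with Liver microsome (Rattus norvegicus) as the target, using microsomes and NADPH, with a stated time of 30 min, at 37 degrees C, tested at 1 uM; a lower number here means slower removal, a higher number faster removal of the compound:
- compound 1 `CC(C)(O)c1ccc(-c2ncc(S(=O)(=O)c3ccc(N)nc3)s2)c(Cl)c1`: 17 mL.min-1.g-1
- compound 2 `Nc1ccc(S(=O)(=O)c2cnc(-c3ccc(S(N)(=O)=O)cc3Cl)s2)cn1`: 107 mL.min-1.g-1

Compound 2 holds the higher of the two numbers, at 107 mL.min-1.g-1. Compound 3 `C[C@@](O)(CO)c1ccc(-c2ncc(S(=O)(=O)c3ccc(N)nc3)s2)c(Cl)c1` differs from it as follows: 1-hydroxy-1-(hydroxymethyl)ethyl in place of sulfamoyl on an aromatic carbon. For the measured compounds named here, the one measured step bearing on this change, a 6.3-fold higher number from compound 1 to compound 2 (0.80 log units; beyond the scatter), brought sulfamoyl in place of 1-hydroxy-1-methylethyl and was modest but beyond the scatter. Removing sulfamoyl is therefore expected to run the other way, with a similar size. The expected step is a 5.9-fold lower number from compound 2 to compound 3 (0.77 log units; beyond the scatter). The estimate for compound 3 is 18 mL.min-1.g-1 (expected range 7 mL.min-1.g-1 to 45 mL.min-1.g-1).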

Compound 3, intrinsic clearance in microsomes: < 14 mL.min-1.g-1
Compound 3 ended at the assay's limit; the forecaster's own chance of this, stated with the estimate: 3%; at least 1.2-fold (0.10 log units) between middle value and limit.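

In this assay compound 3 gives a limit, not a number: the limit of < 14 mL.min-1.g-1 in this assay, at which 1 of the 3 values shown sits.
At this position, 1-hydroxy-1-(hydroxymethyl)ethyl in place of sulfamoyl gives an at least 7.6-fold lower number from compound 2 to compound 3 (0.88 log units; beyond the scatter), so a second group besides 1-hydroxy-1-methylethyl now sits well clear of sulfamoyl. Hydroxy in place of hydrogen on the chain gives an at least 1.2-fold lower number from compound 1 to compound 3 (0.08 log units; that floor lies within the scatter), so no separation between these two chains can be read.

Going by these compounds, how far compound 3 lies past its limit stays open, and with it any real effect of that hydroxy. Also open, on these data alone, is how an amine, a carboxylic acid or a longer chain at this position would read in this assay.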